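Benzyl groups on the shared core: working notes

The source may hold more compounds than are shown below. What is called first, only, known or untested is meant among the compounds shown, and "the series" means these compounds.

Values so far in a functional assay on P388 cells (Mus musculus) for cytotoxicity; on this read-out lower numbers stand for stronger inhibition and higher numbers for weaker inhibition:
- compound 1 `Cc1cc(-c2c(F)cc3c(=O)ccn(C4CC4)c3c2F)cc(C)n1` gives 15000 nM
- compound 2 `COc1ccc(Cc2cn(C3CC3)c3c(F)c(-c4cc(C)nc(C)c4)c(F)cc3c2=O)cc1` gives 21000 nM
- compound 3 `Cc1cc(-c2c(F)cc3c(=O)c(Cc4cccc(O)c4O)cn(C4CC4)c3c2F)cc(C)n1` gives 880 nM

Compound 3 has the lowest number of the three, and its gaps to both others lie beyond the scatter. The next compound to be measured is compound 4 `Cc1cc(-c2c(F)cc3c(=O)c(Cc4c(O)cc(O)cc4O)cn(C4CC4)c3c2F)cc(C)n1`. The change is 2,4,6-trihydroxyphenyl in place of 2,3-dihydroxyphenyl on a saturated chain carbon bound to an aromatic carbon.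

Among the measured compounds shown here, three measured steps bear on this. The 4-methoxybenzyl group gave only a 1.4-fold higher number from compound 1 to compound 2 (0.15 log units; within the scatter), while the 2,3-dihydroxybenzyl group gave a 17-fold lower number from compound 1 to compound 3 (1.23 log units; beyond the scatter) and a 24-fold lower number from compound 2 to compound 3 (1.38 log units; beyond the scatter). For the measured compounds named here, both large steps end at compound 3, so no measured pair tests a change among hydroxy-bearing groups. Compound 4 still carries such a group, so only a small shift in this assay is expected, leaning towards a higher number. The expected step is a 1.7-fold higher number from compound 3 to compound 4 (0.23 log units; within the scatter), with wide uncertainty. For compound 4 the estimated value is 1500 nM, with an expected range from 400 nM to 6000 nM.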

Compound 4, half-maximal inhibitory concentration: 470 nM
Compound 4: the middle estimate sits 3.2-fold (0.50 log units) above what was measured; measured number inside the range.
By their numbers in this assay, from the lowest: compounds 4 and 3 (each within the scatter of the next); then compounds 1 and 2 (each within the scatter of the next).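

In this assay, among the compounds shown here, this is the first comparison of two hydroxy-bearing benzyl groups at this position: the step of a 1.9-fold lower number from compound 3 to compound 4 (0.27 log units; within the scatter) shows that 2,4,6-trihydroxyphenyl and 2,3-dihydroxyphenyl on the saturated chain carbon are not separated by this read-out. The large drop no longer rests on compound 3 alone, since the 2,4,6-trihydroxybenzyl group also gives a step of a 32-fold lower number from compound 1 to compound 4 (1.50 log units; beyond the scatter) and, against the 4-methoxybenzyl group, a step of a 45-fold lower number from compound 2 to compound 4 (1.65 log units; beyond the scatter). Compound 2 goes against any reading that a benzyl group alone is enough, and no measured property is available to account for these steps.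

Still open, as far as these compounds go, is how a 4-hydroxybenzyl group would read at this position, and whether a benzyl group carrying an amine or a carboxylic acid would match the hydroxy-bearing groups. The compounds shown also leave open how many hydroxy groups the large step requires.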